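The source may report more compounds than this note shows. Statements on the series, on what has been measured and on what is new or still open speak of the compounds shown alone.

Measured in an assay on isolated protein for inhibition of DNA topoisomerase 1 (Homo sapiens), with a stated time of 15 min; on this read-out higher numbers stand for weaker inhibition and lower numbers for stronger inhibition:

- compound 1 `CN[C@@H]1CCN(c2cc3c(cc2F)c(=O)c(C(=O)O)cn3Cc2ccc(-c3ccccc3)cc2)C1`: 34800 nM
- compound 2 `O=C(O)c1cn(Cc2ccc(-c3ccccc3)cc2)c2cc(N3CC4CNCC4C3)c(F)cc2c1=O`: 33300 nM
- compound 3 `O=C(O)c1cn(Cc2ccc(-n3cccn3)cc2)c2cc(NC[C@H]3CCNC3)c(F)cc2c1=O`: 187000 nM

Compound 3 stands highest of the three numbers in this assay; compound 1 is nearest and compound 2 furthest, both beyond the scatter. For the measured compounds named here, the one step that is resolved, a 1.0-fold lower number from compound 1 to compound 2 (0.02 log units; within the scatter), concerns the amine substituent only and lies within the scatter, so it does not bear on the change now in question.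

Compound 4 `O=C(O)c1cn(Cc2ccc(-c3ccccc3)cc2)c2cc(NC[C@H]3CCNC3)c(F)cc2c1=O` differs from compound 3 in one place: phenyl in place of 1H-pyrazol-1-yl on an aromatic carbon. Going by the values given here, no measured pair isolates this change, since compound 3 also carries a different amine substituent from compounds 1 and 2. Compound 4 shares the phenyl with compounds 1 and 2, whose numbers are both well lower than that of compound 3, but the amine differs as well, so the expected step is uncertain in size. A move downward in this assay is expected, a 2.9-fold lower number from compound 3 to compound 4 (0.46 log units; beyond the scatter), but with a wide range. Compound 4 is estimated at 65000 nM, between 22000 nM and 190000 nM.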

Compound 4, half-maximal inhibitory concentration: 100000 nM
For compound 4 the middle estimate is 1.5-fold (0.19 log units) below the measured one; low and high end bracket the measured number.
By their numbers in this assay, from the lowest: compounds 2 and 1 (each within the scatter of the next); then compounds 4 and 3 (each within the scatter of the next).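

In this assay, phenyl in place of 1H-pyrazol-1-yl on an aromatic carbon, para to a large group, gives a 1.9-fold lower number from compound 3 to compound 4 (0.27 log units; within the scatter), so on this amine substituent the two groups are not separated. With phenyl held constant, the amine substituent has a modest but resolved effect: ((pyrrolidin-3-yl)methyl)amino in place of 3-(methylamino)pyrrolidin-1-yl gives a 2.9-fold higher number from compound 1 to compound 4 (0.46 log units; beyond the scatter), and the same amine in place of the two-ring group of compound 2 gives a 3.0-fold higher number from compound 2 to compound 4 (0.48 log units; beyond the scatter). No measurement is at hand that accounts for these steps.

From the compounds shown here alone, it remains open whether phenyl and 1H-pyrazol-1-yl also stay unresolved when paired with the amine substituents of compounds 1 and 2. Also open, going by these compounds, is how a pyridin-3-yl ring or a carboxylic acid in place of the phenyl would read out.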